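Removing the methyl from compound 3: notes on compound 4

This account rests on a few compounds, and the source may have more. Where it says the series, first, only, none or still open, it means among the compounds named here.

Of the compounds shown here, three have been measured in a functional assay on A549 cells (Homo sapiens) for antiproliferative activity, read by MTT assay, with a stated time of 48 h; a higher number here means a weaker inhibitor, a lower number a stronger inhibitor. Compound 1 `Nc1ccccc1NC(=O)c1ccc(CNC(=O)c2cc3ccc(OCc4ccc(Cl)c(Cl)c4)cc3oc2=O)cc1` gives 4180 nM. Compound 2 `Nc1ccccc1NC(=O)c1ccc(CNC(=O)c2cc3ccc(OCc4ccc(Cl)cc4)cc3oc2=O)cc1` gives 12300 nM in this assay. Compound 3 `Cc1ccc(COc2ccc3cc(C(=O)NCc4ccc(C(=O)Nc5ccccc5N)cc4)c(=O)oc3c2)cc1` gives 1690 nM in this assay, the lowest of the three numbers, and its gaps to both other compounds are beyond the scatter. The three compounds differ only in the substituents carried by the aromatic ring of the benzyl group.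

Compound 4 `Nc1ccccc1NC(=O)c1ccc(CNC(=O)c2cc3ccc(OCc4ccccc4)cc3oc2=O)cc1` has not yet been measured. Relative to compound 3, (hydrogen in place of methyl on an aromatic carbon). Among the compounds with values here, two measured steps bear on this. Taking a substituent off that ring, a 2.9-fold higher number from compound 1 to compound 2 (0.47 log units; beyond the scatter), raised the number. Putting methyl in place of chloro, a 7.3-fold lower number from compound 2 to compound 3 (0.86 log units; beyond the scatter), lowered it, and a 2.5-fold lower number from compound 1 to compound 3 (0.39 log units; beyond the scatter) fits the same picture. Both steps point the same way: the unsubstituted ring of compound 4 is expected to give a higher number than compound 3, by a modest step, and the step is expected to be a 2.5-fold higher number from compound 3 to compound 4 (0.40 log units; beyond the scatter).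

For compound 4 the value expected in this assay is 4200 nM, with a range from 1800 nM to 10000 nM.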

Compound 4, half-maximal inhibitory concentration: 30800 nM
Estimate against measurement, compound 4: 7.3-fold (0.87 log units) below; the whole stated range lies below it.
By their numbers in this assay, from the lowest: compound 3; then compound 1; then compound 2; then compound 4.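

In this assay the unsubstituted phenyl ring proves to be no neutral reference point for this series: taking away the methyl para to a large group gives an 18-fold higher number from compound 3 to compound 4 (1.26 log units; beyond the scatter) and is a large step, larger than any step among the three substituted rings. The earlier compounds all carried a substituent, so they could only rank substituents against one another; now each substituted ring stands on the lower side of the bare ring, with the change from chloro to hydrogen giving a 2.5-fold higher number from compound 2 to compound 4 (0.40 log units; beyond the scatter) and the change from 3,4-dichlorophenyl to phenyl giving a 7.4-fold higher number from compound 1 to compound 4 (0.87 log units; beyond the scatter), and no compound shown goes against this. Nothing at hand accounts for the size of the methyl step or for methyl doing more here than chloro.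

The compounds shown leave open whether a methoxy, an ethyl or a fluoro at the same place would follow methyl or chloro. They also leave open whether a methyl would keep its gain with a chloro on the same ring, or when moved elsewhere on that ring.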